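Swapping a methyl for methanesulfonamido on the aromatic ring

A few compounds are considered here, and "the series" means these few. Any claim that something is new, unique, unknown or untested is made for them only; others in the source may bear on it.

Three compounds that share a dithiocarbonate-style side chain attached through a ketone to an aromatic ring have been measured in an assay on HEK293 cells for inhibition of protein deacetylase HDAC6 (Homo sapiens); a higher number here means a weaker inhibitor, a lower number a stronger inhibitor. Compound 1 `CCSC(=S)SCC(=O)c1cccc(C(=O)NCc2ccccc2)c1` gives 195 nM. Compound 2 `CCSC(=S)SCC(=O)c1ccc(C)cc1` gives 1250 nM, the highest number of the three and therefore the weakest inhibitor: compound 1 sits a long way below it, and compound 3 `CCOC(=S)SCC(=O)c1ccc(NC(C)=O)cc1`, which gives 90 nM in this assay, sits further still, both gaps being beyond the usual scatter.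

Compound 4 `CCSC(=S)SCC(=O)c1ccc(NS(C)(=O)=O)cc1` has not yet been measured. It differs from compound 2 in one place: methanesulfonamido in place of methyl on an aromatic carbon. Among the compounds with values here, no pair of measured compounds shows this exact change, so the expected effect can only be read from where compound 2 stands, at the weak end, with the other two compounds well below it.

Compound 4 is therefore expected to move toward the stronger compounds, a step from compound 2 to compound 4 of a 5.0-fold lower number from compound 2 to compound 4 (0.70 log units; beyond the scatter), in the direction of a lower number. The estimate for compound 4 in this assay is 250 nM, with a likely range from 80 nM to 800 nM.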

Compound 4, half-maximal inhibitory concentration: 1090 nM
The estimate for compound 4 lay 4.4-fold (0.64 log units) below the measured number; measured number above the stated range.
By their numbers in this assay, from the lowest: compound 3; then compound 1; then compounds 4 and 2 (each within the scatter of the next).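

In this assay, placing methanesulfonamido instead of methyl on this aromatic carbon gives a 1.1-fold lower number from compound 2 to compound 4 (0.06 log units; within the scatter), so the number stays within the scatter. At this position, para to a group of 9 heavy atoms, a much larger group that adds a hydrogen-bond donor and hydrogen-bond acceptors therefore brings no measurable change in this assay. No measurement shown here accounts for this flat result.

Going by these compounds, whether an amine or a carboxylic acid on the same aromatic carbon would shift the number remains open. Within the data shown here, compound 3 differs from compound 2 and from compound 4 in more than one place, as does compound 1, so no step to any of them can be read and their numbers cannot be tied to a single group.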